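Dropping the methyl from compound 1: a solubility outlook

The compounds below may be only part of what the source reports. "The series", "measured", "known", "first", "only" and "open" are said of these compounds alone.

compound 1 `CNC(=O)c1cc(C(=O)N[C@H]2CC[C@H](O)CC2)c([C@@H](C)c2cccc(C)c2)o1`: > 1000 ug/mL
compound 2 `CNC(=O)c1cc(C(=O)NC2CC2)cn([C@H](C)c2ccccc2)c1=O`: 815 ug/mL
compound 3 `CC(=O)Nc1c(F)cc(C(=O)N[C@H]2CC[C@H](O)CC2)cc1O[C@@H](C)c1ccccc1`: 996 ug/mL

Of the compounds shown here, three have been measured in a physicochemical assay for solubility, read by HPLC, in simulated intestinal fluid, with a stated time of 16 h, at pH 6.5; a lower number here means a less soluble compound, a higher number a more soluble compound. Compound 1 sits at the limit of > 1000 ug/mL in this assay, at which 1 of the 3 values shown sits, so its reading is a limit of the assay rather than a number. Compound 2 gives 815 ug/mL in this assay. Compound 3 gives 996 ug/mL in this assay. Going by the values given here, no two of these three differ in just one place, so no measured step can guide the next one directly.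

Compound 4 `CNC(=O)c1cc(C(=O)N[C@H]2CC[C@H](O)CC2)c([C@@H](C)c2ccccc2)o1` differs from compound 1 by hydrogen in place of methyl on an aromatic carbon. This small change is expected to shift this assay little, none beyond the scatter. Compound 4 is therefore estimated at 1200 ug/mL, within 700 ug/mL to 2500 ug/mL. The expected step is a step that the limit leaves unreadable from compound 1 to compound 4, and a limit reading is again expected to be the likeliest outcome.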

Compound 4, solubility: 827 ug/mL
For compound 4 the middle estimate is 1.5-fold (0.16 log units) above the measured one; the range from low to high includes it.
By their numbers in this assay, from the lowest: compounds 2, 4 and 3 (each within the scatter of the next). At a limit, above all of these: compound 1.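

In this assay the change from 3-methylphenyl to phenyl gives an at least 1.2-fold lower number from compound 1 to compound 4 (0.08 log units; that floor lies within the scatter) on this aromatic carbon. Compound 4 gives 827 ug/mL as a plain number, so this series now has a measured reading with hydrogen at this position. The reading of compound 1 is a limit, so the true size of the step cannot be read: the limit of > 1000 ug/mL in this assay, at which 1 of the 4 values shown sits.

From the compounds shown here alone, whether another group on this carbon, such as an amine, a carboxylic acid or a chlorine atom, would move the number beyond the scatter remains open.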